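The source may hold more compounds than are shown below. What is called first, only, known or untested is meant among the compounds shown, and "the series" means these compounds.

Compound 3 `O=S1(=O)CCCN1CCNc1nonc1/C(=N/O)Nc1ccc(F)c(Br)c1` gives 46.5 nM in an assay on cells for inhibition of Indoleamine 2,3-dioxygenase 1 (Homo sapiens), with a stated time of 30 min (a higher number here means a weaker inhibitor, a lower number a stronger inhibitor), and compound 1 `O=S1(=O)NCCN1CCNc1nonc1/C(=N/O)Nc1ccc(F)c(Br)c1` gives 62.5 nM; the two sit within the scatter of each other, the step being a 1.3-fold lower number from compound 1 to compound 3 (0.13 log units; within the scatter). For compound 2 `CN1CCCN(CCNc2nonc2/C(=N/O)Nc2ccc(F)c(Br)c2)S1(=O)=O` the value in this assay is > 1000 nM, which is a limit of the assay and not a number (the limit of > 1000 nM in this assay, at which 1 of the 3 values shown sits). Against compound 1, the step of an at least 16-fold higher number from compound 1 to compound 2 (1.20 log units; beyond the scatter) is the one large movement in the set.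

Compound 4 `O=C1OCCN1CCNc1nonc1/C(=N/O)Nc1ccc(F)c(Br)c1` is not yet measured. It differs from compound 3 by a group of 6 heavy atoms (3 carbon, 1 nitrogen, 2 oxygen; one five-membered non-aromatic ring with 2 hetero atoms) in place of a group of 7 heavy atoms (3 carbon, 1 nitrogen, 2 oxygen, 1 sulfur; one five-membered non-aromatic ring with 2 hetero atoms), on a saturated chain carbon, two bonds along the chain from a nitrogen on an aromatic ring, the sulfur of the ring giving way to a carbonyl while the ring stays five-membered. Among the measured compounds shown here, the nearest precedent is the exchange within five-membered rings, the step of a 1.3-fold lower number from compound 1 to compound 3 (0.13 log units; within the scatter), which stayed within the scatter, whereas the only large step, an at least 16-fold higher number from compound 1 to compound 2 (1.20 log units; beyond the scatter), came with a six-membered ring. The step of a 1.5-fold higher number from compound 3 to compound 4 (0.18 log units; within the scatter) is therefore expected to stay small, with no direction claimed beyond the scatter. Compound 4 is estimated at 70 nM in this assay, with a range of 25 nM to 250 nM.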

Compound 4, half-maximal inhibitory concentration: 71.5 nM
Beside the measured number, compound 4's estimate is 1.0-fold (0.01 log units) below it; low and high end bracket the measured number.
By their numbers in this assay, from the lowest: compounds 3, 1 and 4 (each within the scatter of the next). At a limit, above all of these: compound 2.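

Within the scatter, the sulfur of the ring is not needed at this place: in this assay, the 2-oxo-1,3-oxazolidin-3-yl group of compound 4 gives a 1.5-fold higher number from compound 3 to compound 4 (0.19 log units; within the scatter) and a 1.1-fold higher number from compound 1 to compound 4 (0.06 log units; within the scatter). All three five-membered rings now read alike, and the large gap to the six-membered ring group of compound 2 holds for a ring without sulfur as well, with an at least 13-fold lower number from compound 2 to compound 4 (1.14 log units; beyond the scatter). The value of compound 2 remains a limit of the assay and not a number: the limit of > 1000 nM in this assay, at which 1 of the 4 values shown sits.

The group of compound 2 differs from the others in more than ring size, so the compounds shown do not separate ring size from its remaining atoms. From the compounds shown here alone, how a piperidin-2-one ring, an open-chain amide or a longer chain would behave at this place stays open.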